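A methoxy added to compound 3

The source may report more compounds than this note shows. Statements on the series, on what has been measured and on what is new or still open speak of the compounds shown alone.

In a functional assay on SK-MEL cells (Homo sapiens) for cytotoxicity, read by MTT assay, with a stated time of 6 days (on this read-out higher numbers stand for an effect only at larger amounts of compound and lower numbers for an effect already at smaller amounts), compound 3 `COC(=O)c1c(-c2ccc(O)cc2)oc2ccccc2c1=O` gives > 25 ug/mL, which is a limit and not a number. Compound 2 `COC(=O)c1c(-c2ccc(OCc3ccccc3)cc2)oc2ccccc2c1=O` gives > 25 ug/mL, which is also a limit. Compound 3 therefore stands at the limit of > 25 ug/mL in this assay, at which 2 of the 3 values shown sit. Only compound 1 `COC(=O)c1c(-c2ccc([N+](=O)[O-])cc2)oc2cc(OC)ccc2c1=O` has a number in this assay, at 2.84 ug/mL.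

Compound 4 `COC(=O)c1c(-c2ccc(O)cc2)oc2cc(OC)ccc2c1=O` follows from compound 3 with methoxy in place of hydrogen on an aromatic carbon. Among the measured compounds shown here, the one measured step is a step that the two limits leave unreadable from compound 2 to compound 3. For the measured compounds named here, it concerns a different change, so it offers no size to carry over, and no measured step isolates the methoxy group. Compound 1 also carries a methoxy group and reads 2.84 ug/mL, which is the only hint of direction. A moderate shift towards lower numbers is therefore expected, and the result may well remain a limit. The expected move is an at least 1.6-fold lower number from compound 3 to compound 4 (0.22 log units; that floor lies within the scatter). Compound 4 is estimated at 15 ug/mL, with an expected range of 4 ug/mL to 40 ug/mL.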

Compound 4, concentration for half-maximal effect: 19.6 ug/mL
Compound 4: the middle estimate sits 1.3-fold (0.12 log units) below what was measured, and the stated range covers the measured number.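

In this assay, methoxy in place of hydrogen on this aromatic carbon gives an at least 1.2-fold lower number from compound 3 to compound 4 (0.10 log units; that floor lies within the scatter), so the change can be read only as a floor. Among the compounds shown here, that floor cannot be sharpened because compound 3 has a limit and not a number: the limit of > 25 ug/mL in this assay, at which 2 of the 4 values shown sit. With the methoxy group shared, hydroxy in place of nitro on an aromatic carbon gives a 6.9-fold higher number from compound 1 to compound 4 (0.84 log units; beyond the scatter), the first step between two numbers, and it shows that this second change can be sized where the methoxy change cannot.

As far as these compounds go, it remains open whether a longer chain such as ethoxy in place of methoxy at this position would give a step beyond the scatter. From the compounds shown here alone, it also remains open whether an amine in place of the nitro or hydroxy group would read closer to compound 1 or to compound 4.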